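Repeating One Methyl Step on a Polar Oxime Scaffold

A few compounds are considered here, and "the series" means these few. Any claim that something is new, unique, unknown or untested is made for them only; others in the source may bear on it.

Compound 1 `CC[n+]1ccn(CCN(C)C)c1/C=N/O` and compound 2 `CCC[n+]1ccn(CCN(C)C)c1/C=N/O` differ in a single place, (methyl in place of hydrogen on a saturated chain carbon, two bonds along the chain from an aromatic nitrogen). In a physicochemical assay for lipophilicity (a lower number here means a more polar compound, a higher number a more lipophilic compound), compound 1 gives -2.71. In this assay compound 2 gives -2.73. The measured step is a number 0.02 log units lower from compound 1 to compound 2 (within the scatter). Compound 3 `CC[n+]1ccn(COCCS(C)(=O)=O)c1/C=N/O` carries another side chain on the ring; the difference between its core and the core of compound 1 is not broken down here. In this assay compound 3 gives < -3, which is a limit of the assay and not a number, as the limit of < -3 in this assay, at which 1 of the 3 values shown sits, shows. Compound 4 `CCC[n+]1ccn(COCCS(C)(=O)=O)c1/C=N/O` differs from compound 3 by the same change, (methyl in place of hydrogen on a saturated chain carbon, two bonds along the chain from an aromatic nitrogen). The step from compound 3 to compound 4 is expected to be a step that the limit leaves unreadable from compound 3 to compound 4 because the matching measured step is a number 0.02 log units lower from compound 1 to compound 2 (within the scatter). Compound 4 is therefore estimated at -3.1, most likely again reported only as a limit.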

Compound 4, distribution coefficient: < -3
Compound 4 was reported as a limit; the forecaster's own chance of this, stated with the estimate: 85%; the middle value is on the limit's open side.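

Compound 3 and compound 4 are both reported only as a limit of the assay and not as a number, so no step between them can be read: the limit of < -3 in this assay, at which 2 of the 4 values shown sit.

On these data alone, whether the methyl step has the same size with their side chain as with that of compound 1 and compound 2 stays open.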